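Notes on the series: difluoromethoxy pyridine to diethylthio pyridine

This account rests on a few compounds, and the source may have more. Where it says the series, first, only, none or still open, it means among the compounds named here.

Measured so far in an ADME assay on microsomes from liver (Homo sapiens) for metabolic stability; on this read-out higher numbers stand for fast clearance and lower numbers for slow clearance:
- compound 1 `COc1cc([C@](O)(CCN(C)C)[C@@H](c2cc3cc(Br)ccc3nc2OC)c2cccc(OC)c2F)cc(OC(F)F)n1`: 0.1 uL/min
- compound 2 `COc1cc([C@](O)(CCN(C)C)[C@@H](c2cc3cc(Br)ccc3nc2OC)c2ccnc(OC)c2OC)cc(OC(F)F)n1`: 2.1 uL/min

Compound 1 stands lowest of the two numbers. Its nearest neighbour is compound 2, reached by a 21-fold higher number from compound 1 to compound 2 (1.32 log units; beyond the scatter), a change of the aryl group on the saturated chain carbon bound to an aromatic carbon and a saturated chain carbon.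

Compound 3 `CCSc1cc([C@](O)(CCN(C)C)[C@@H](c2cc3cc(Br)ccc3nc2OC)c2cccc(OC)c2F)cc(SCC)n1` has not been measured. It differs from compound 1 by a group of 12 heavy atoms (9 carbon, 1 nitrogen, 2 sulfur; one six-membered aromatic ring with 1 hetero atom) in place of a group of 12 heavy atoms (7 carbon, 1 nitrogen, 2 oxygen, 2 fluorine; one six-membered aromatic ring with 1 hetero atom), on a saturated chain carbon bound to an oxygen on a saturated carbon and two saturated chain carbons.

Among the compounds with values here, no measured step touches this place; the single known step concerns a different part of the core and so gives no direct guide, beyond showing that this assay can move far. The direction for compound 3 is therefore open. With compound 1 at 0.1 uL/min as the starting point, the expected value for compound 3 is 0.8 uL/min, with a range from 0.1 uL/min to 6 uL/min. The estimated step is an 8.0-fold higher number from compound 1 to compound 3 (0.90 log units; beyond the scatter).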

Compound 3, intrinsic clearance in a liver preparation (reported as CLH), per the amount of preparation that the assay uses: 4.9 uL/min
Compound 3: the middle estimate sits 6.1-fold (0.79 log units) below what was measured; measured number inside the range.
By their numbers in this assay, from the lowest: compound 1; then compound 2; then compound 3.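

In this assay, the place on a saturated chain carbon bound to an oxygen on a saturated carbon and two saturated chain carbons also moves the read-out, with a 49-fold higher number from compound 1 to compound 3 (1.69 log units; beyond the scatter) on going from the difluoromethoxy pyridine to the diethylthio pyridine. Compound 1 therefore stands lowest against changes at two different places, so its low number does not depend on the aryl group alone. Nothing measured here bears on why this change raises the number.

The swap replaces both groups on the pyridine at once, so the compounds shown leave open how much of the step belongs to the ethylthio group that takes the place of the methoxy group and how much to the one that takes the place of the difluoromethoxy group. A pyridine carrying one ethylthio group and one methoxy group would divide the step, and an ethoxy group would set an oxygen against the sulfur in the same chain.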